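The source may hold more compounds than are shown below. What is called first, only, known or untested is meant among the compounds shown, and "the series" means these compounds.

Three compounds of this series have numbers in a functional assay on LNCaP cells (Homo sapiens) for antiproliferative activity; a higher number here means a weaker inhibitor, a lower number a stronger inhibitor. Compound 1 `Cn1ncc(Cl)c1-c1cc(C(=O)N[C@@H]2CN[C@H](CC(=O)O)C[C@H]2c2ccc(Cl)c(Cl)c2)oc1Cl` carries carboxy on a saturated chain carbon bound to a saturated ring carbon; in this assay compound 1 gives 640 nM. Compound 2 `Cn1ncc(Cl)c1-c1cc(C(=O)N[C@@H]2CN[C@H](CCN3CCC(O)CC3)C[C@H]2c2ccc(Cl)c(Cl)c2)oc1Cl` has (4-hydroxypiperidin-1-yl)methyl at that place, and compound 2 gives 1140 nM. Compound 3 `C=CC[C@@H]1C[C@@H](c2ccc(Cl)c(Cl)c2)[C@H](NC(=O)c2cc(-c3c(Cl)cnn3C)c(Cl)o2)CN1` has vinyl there, and compound 3 gives 160 nM, the lowest of the three numbers. The steps between them run a 1.8-fold higher number from compound 1 to compound 2 (0.25 log units; within the scatter), a 4.0-fold lower number from compound 1 to compound 3 (0.60 log units; beyond the scatter) and a 7.1-fold lower number from compound 2 to compound 3 (0.85 log units; beyond the scatter); compound 3 stands apart from both others beyond the scatter, while compound 1 and compound 2 sit within the scatter of each other.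

Compound 4 `Cn1ncc(Cl)c1-c1cc(C(=O)N[C@@H]2CN[C@H](CCN3CCCC3)C[C@H]2c2ccc(Cl)c(Cl)c2)oc1Cl` is the next member. Against compound 3 the change is (pyrrolidin-1-yl)methyl in place of vinyl on a saturated chain carbon bound to a saturated ring carbon. The precedent that bears most directly is a 7.1-fold lower number from compound 2 to compound 3 (0.85 log units; beyond the scatter), since compound 2 also carries a non-aromatic ring with one hetero atom attached through a methylene at the same place; compound 4 reverses that kind of change. The step of a 1.8-fold higher number from compound 1 to compound 2 (0.25 log units; within the scatter) adds that such a group and carboxy gave numbers within the scatter of each other. A return toward the numbers of compound 1 and compound 2 is therefore expected, as a 4.4-fold higher number from compound 3 to compound 4 (0.64 log units; beyond the scatter). Compound 4 is estimated at 700 nM, with a range from 250 nM to 2000 nM.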

Compound 4, half-maximal inhibitory concentration: 1920 nM
For compound 4 the middle estimate is 2.7-fold (0.44 log units) below the measured one; low and high end bracket the measured number.
By their numbers in this assay, from the lowest: compound 3; then compounds 1, 2 and 4 (each within the scatter of the next, the first and the last beyond it).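

In this assay (pyrrolidin-1-yl)methyl in place of vinyl on a saturated chain carbon bound to a saturated ring carbon gives a 12-fold higher number from compound 3 to compound 4 (1.08 log units; beyond the scatter) and so provides a second ring-bearing group that stands apart from vinyl beyond the scatter, after the (4-hydroxypiperidin-1-yl)methyl of compound 2. The two ring-bearing groups themselves cannot be separated here: pyrrolidin-1-yl in place of 4-hydroxypiperidin-1-yl gives a 1.7-fold higher number from compound 2 to compound 4 (0.23 log units; within the scatter) and stays within the scatter. Carboxy and (pyrrolidin-1-yl)methyl do separate, with a 3.0-fold higher number from compound 1 to compound 4 (0.48 log units; beyond the scatter) lying beyond the scatter, whereas carboxy and (4-hydroxypiperidin-1-yl)methyl did not, so the (4-hydroxypiperidin-1-yl)methyl group sits within the scatter of both. Nothing available on these compounds accounts for any of these differences.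

Going by these compounds, it remains open whether the low number of compound 3 depends on the double bond of the vinyl group, which a saturated ethyl group at the same place would test. On these data alone, it is also open whether an open-chain amine such as dimethylamino, or a primary amide in place of carboxy, would fall with compound 3 or with the other three compounds.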